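This account rests on a few compounds, and the source may have more. Where it says the series, first, only, none or still open, it means among the compounds named here.

Measured in an ADME assay on L02 cells (Homo sapiens) for cytotoxicity, read by MTT assay; on this read-out higher numbers stand for weaker inhibition and lower numbers for stronger inhibition:
- compound 1 `C#CCOc1cc(/C=C/C(=O)c2ccc(OC)c3c2OC(C)(C)C=C3)ccc1OC`: compound 1 gives > 10000 nM, a limit of the assay.
- compound 2 `C=CCOc1cc(/C=C/C(=O)c2ccc(OC)c3c2OC(C)(C)C=C3)ccc1OC`: compound 2 gives > 20000 nM, a limit of the assay.
- compound 3 `C=CC(=O)Oc1cc(/C=C/C(=O)c2ccc(OC)c3c2OC(C)(C)C=C3)ccc1OC`: compound 3 gives > 10000 nM, a limit of the assay.

Compound 1 thus stands only at a limit in this assay, and the two other values are likewise limits. The steps a step that the two limits leave unreadable from compound 1 to compound 2, a step that the two limits leave unreadable from compound 1 to compound 3 and a step that the two limits leave unreadable from compound 2 to compound 3 are all left unreadable, as the limit of > 10000 nM in this assay, at which 2 of the 3 values shown sit, and the limit of > 20000 nM in this assay, at which 1 of the 3 values shown sits, show. Compound 4 `COc1ccc(/C=C/C(=O)c2ccc(OC)c3c2OC(C)(C)C=C3)cc1OC(=O)c1ccc(Br)cc1` carries the change ((4-bromophenyl)carbonyl in place of propargyl on an oxygen on an aromatic ring). The measured steps alter the same oxygen on an aromatic ring, yet none yields a readable size, so no direction can be drawn from them. For a step that the limit leaves unreadable from compound 1 to compound 4 no step beyond the scatter is expected. Compound 4 is therefore expected at 15000 nM (range 7000 nM to 40000 nM), most likely reported again only as a limit.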

Compound 4, half-maximal inhibitory concentration: 8400 nM
Compound 4: the middle estimate sits 1.8-fold (0.25 log units) above what was measured; the measured number falls inside the stated range.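

In this assay, going by these compounds alone, compound 4 gives 8400 nM, the only value shown at this oxygen on an aromatic ring that is not a limit. Exchanging allyl for (4-bromophenyl)carbonyl gives an at least 2.3-fold lower number from compound 2 to compound 4 (0.37 log units; beyond the scatter), the one floor beyond the scatter. The other two steps, an at least 1.1-fold lower number from compound 1 to compound 4 (0.07 log units; that floor lies within the scatter) and an at least 1.1-fold lower number from compound 3 to compound 4 (0.07 log units; that floor lies within the scatter), have floors within the scatter, so they establish no change.

The steps among the three limit compounds remain unreadable. Also open, from the compounds shown here alone, is whether the bromine or the aromatic ring accounts for the readable value, and how a chain ending in an amine or a carboxylic acid would read at this oxygen.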